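Trifluoromethyl in place of methyl on compound 2

A few compounds are considered here, and "the series" means these few. Any claim that something is new, unique, unknown or untested is made for them only; others in the source may bear on it.

Of the compounds shown here, three sharing one core have been measured in an ADME assay on the whole organism for pharmacokinetics, with Rattus norvegicus as the target, with a stated time of 24 h, at a dose of 5 mg/kg by the oral route; on this read-out lower numbers stand for lower exposure and higher numbers for higher exposure at the dose given. Compound 1 (`Cc1nc2ccccc2c2c1O[C@]1(CC2)C[C@H]2C(=O)N[C@]3(C(=O)NS(=O)(=O)C4(C)CC4)C[C@H]3/C=C\CCCCC[C@H](NC(=O)OC(C)(C)C)C(=O)N2C1`) gives 105 ng.h/mL, compound 2 (`COc1ccc2nc(C)c3c(c2c1)CC[C@]1(C[C@H]2C(=O)N[C@]4(C(=O)NS(=O)(=O)C5(C)CC5)C[C@H]4/C=C\CCCCC[C@H](NC(=O)OC(C)(C)C)C(=O)N2C1)O3`) gives 62.4 ng.h/mL and compound 3 (`COc1ccc2nc(C)c3c(c2c1)CC[C@]1(C[C@H]2C(=O)N[C@]4(C(=O)NS(=O)(=O)C5(C)CC5)C[C@H]4/C=C\CCCCC[C@H](NC(=O)OCC(C)C)C(=O)N2C1)O3`) gives 101 ng.h/mL. The value for compound 2 therefore lies within the scatter of the other two, and the set offers no clear separation. The two measured steps show this directly. With methoxy in place of hydrogen on an aromatic carbon, the step is a 1.7-fold lower number from compound 1 to compound 2 (0.23 log units; within the scatter). With isobutyl in place of tert-butyl on an oxygen next to a carbonyl group, it is a 1.6-fold higher number from compound 2 to compound 3 (0.21 log units; within the scatter).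

Compound 4 (`COc1ccc2nc(C(F)(F)F)c3c(c2c1)CC[C@]1(C[C@H]2C(=O)N[C@]4(C(=O)NS(=O)(=O)C5(C)CC5)C[C@H]4/C=C\CCCCC[C@H](NC(=O)OC(C)(C)C)C(=O)N2C1)O3`) has not yet been measured in this assay. It differs from compound 2 by a single change: trifluoromethyl in place of methyl on an aromatic carbon. This is trifluoromethyl in place of methyl on an aromatic carbon. Within the data shown here, neither measured step involves that carbon, so the data give no direct precedent for the change and bear on it only indirectly. Both steps elsewhere on the structure stayed within the scatter, so no step beyond the scatter is expected here, though the uncertainty is wide. The expected step is a 1.1-fold higher number from compound 2 to compound 4 (0.05 log units; within the scatter). For compound 4 the estimated value is 70 ng.h/mL, with an expected range of 28 ng.h/mL to 175 ng.h/mL.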

Compound 4, area under the concentration-time curve: 1670 ng.h/mL
Estimate against measurement, compound 4: 24-fold (1.38 log units) below; the whole stated range lies below it.
By their numbers in this assay, from the lowest: compounds 2, 3 and 1 (each within the scatter of the next); then compound 4.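

In this assay, among these compounds, the aromatic carbon next to the ring nitrogen is the first place on this structure where a single change gives a step beyond the scatter: trifluoromethyl in place of methyl gives a 27-fold higher number from compound 2 to compound 4 (1.43 log units; beyond the scatter) in the same core. The two earlier steps, one at the methoxy on an aromatic carbon and one at the group on the oxygen next to a carbonyl group, stayed within the scatter, so they gave no sign that one substitution could move this read-out so far. No measurement available here accounts for the size of this step, and the reason for it stays unknown.

Whether the step belongs to trifluoromethyl itself remains open, since the compounds shown do not tell whether difluoromethyl, a chlorine atom or a cyclopropyl group on the same carbon would give a similar result. Going by these compounds, it is also open whether trifluoromethyl would give a step of this size with hydrogen in place of the methoxy, as in compound 1, or with isobutyl in place of tert-butyl, as in compound 3.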